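Notes on the step from compound 2 to compound 4

The source may report more compounds than this note shows. Statements on the series, on what has been measured and on what is new or still open speak of the compounds shown alone.

Compound 2 `Cc1cnc(Nc2ccc(C(C)C)cc2)nc1Nc1nc2ccccc2s1` stands at a limit: in a functional assay on MDA-MB-231 cells (Homo sapiens) for antiproliferative activity, read by MTT assay, with a stated time of 48 h (on this read-out higher numbers stand for weaker inhibition and lower numbers for stronger inhibition), compound 2 gives > 50000 nM, which is the boundary described by the limit of > 50000 nM in this assay, at which 1 of the 3 values shown sits, and not a number. Compound 3 `Cc1cnc(Nc2ccc(S(C)(=O)=O)cc2)nc1Nc1nc2ccccc2s1` gives 14800 nM in this assay. Compound 1 `Cc1ccc2nc(Nc3nc(Nc4ccc(S(N)(=O)=O)cc4)ncc3F)sc2c1`, built on a different core, gives 6390 nM in this assay. Among the measured compounds shown here, the only measured step at the same position is an at least 3.3-fold lower number from compound 2 to compound 3 (0.52 log units; beyond the scatter), showing that swapping the group on that aromatic ring can move the read-out beyond the scatter, though only a bound is known for it.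

Compound 4 `COc1cccc(Nc2ncc(C)c(Nc3nc4ccccc4s3)n2)c1` is not yet measured; it differs from compound 2 by 3-methoxyphenyl in place of 4-isopropylphenyl on a nitrogen on an aromatic ring. For the measured compounds named here, no measured pair exchanges an isopropyl for a methoxy group, so the size of this step is open. Since compound 2 gives only a limit, a lower number is the more likely outcome for compound 4 in this assay. Compound 4 is expected to give about 30000 nM in this assay, within 10000 nM to 60000 nM. The expected step from compound 2 to compound 4 is estimated at an at least 1.6-fold lower number from compound 2 to compound 4 (0.22 log units; that floor lies within the scatter) and may not be resolved against the limit.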

Compound 4, half-maximal inhibitory concentration: > 50000 nM
Compound 4: only a limit was reported; the forecaster's own chance of this, stated with the estimate: 40%; at least 1.6-fold (0.22 log units) between middle value and limit.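

Compound 2 and compound 4 both stand at a limit and not at a number, so no step can be read between them: the limit of > 50000 nM in this assay, at which 2 of the 4 values shown sit. From the compounds shown here alone, whether 3-methoxyphenyl in place of 4-isopropylphenyl changes the read-out in this assay at all remains open.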